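The source may report more compounds than this note shows. Statements on the series, on what has been measured and on what is new or still open speak of the compounds shown alone.

Measured compounds:
- compound 1, `CC(C)c1ccc(Nc2ccc3c(OCCCN4CCN(C)CC4)cccc3n2)cc1`: 2050 nM
- compound 2, `CN1CCN(CCCOc2cccc3nc(Nc4ccc(F)c(F)c4)ccc23)CC1`: 660 nM

In a functional assay on K562 cells (Homo sapiens) for inhibition, read by sulforhodamine B assay, with a stated time of 48 h (a lower number here means a stronger inhibitor of growth, a higher number a weaker inhibitor of growth), compound 2 gives 660 nM, the lowest of the two numbers measured; its nearest neighbour is compound 1, and the step of a 3.1-fold lower number from compound 1 to compound 2 (0.49 log units; beyond the scatter) lies beyond the scatter. Compound 3, `CN1CCN(CCCOc2cccc3nc(Nc4cc(Cl)cc(Cl)c4)ccc23)CC1`, has not yet been measured. It differs from compound 2 in one place: 3,5-dichlorophenyl in place of 3,4-difluorophenyl on a nitrogen on an aromatic ring.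

Within the data shown here, only one measured step bears on this change, a 3.1-fold lower number from compound 1 to compound 2 (0.49 log units; beyond the scatter), which shows that swapping the group on this nitrogen can move the number by a modest amount. That step exchanged a different pair of groups, so it gives no direct guide to the direction here. With the two halogens kept and only their kind and placement altered, compound 3 is expected to land close to compound 2, with a step of about a 1.2-fold higher number from compound 2 to compound 3 (0.08 log units; within the scatter) that may well stay within the scatter. The estimate for compound 3 is 800 nM, in the range 250 nM to 2500 nM.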

Compound 3, concentration for 50% growth inhibition: 1660 nM
Beside the measured number, compound 3's estimate is 2.1-fold (0.32 log units) below it, within the range that was stated.
By their numbers in this assay, from the lowest: compound 2; then compounds 3 and 1 (each within the scatter of the next).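

In this assay, keeping two halogens on the phenyl ring does not by itself hold the number steady: 3,5-dichlorophenyl in place of 3,4-difluorophenyl on this nitrogen gives a 2.5-fold higher number from compound 2 to compound 3 (0.40 log units; beyond the scatter), so the kind or placement of the halogens matters here. Replacing 4-isopropylphenyl with 3,5-dichlorophenyl gives a 1.2-fold lower number from compound 1 to compound 3 (0.09 log units; within the scatter), so among these three compounds only the 3,4-difluorophenyl group stands apart. Nothing available explains why this group differs from the other two.

Halogen kind and placement changed together from compound 2 to compound 3, so their separate contributions remain open; 3,5-difluorophenyl or 3,4-dichlorophenyl would pull them apart. From the compounds shown here alone, how a methoxy group or an amine on this phenyl ring would compare also remains unknown.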